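Small alkyl changes on a scaffold that shows no cytotoxicity

The source may hold more compounds than are shown below. What is called first, only, known or untested is meant among the compounds shown, and "the series" means these compounds.

Compound 1 `CCO[C@@]1(CC)CCC2(CO1)[C@@H]1CCC3=C4[C@@H](CC3=O)[C@H](C(=O)OC)C[C@@]42CN(C)C1` and compound 2 `CC[C@]1(OC)CCC2(CO1)[C@@H]1CCC3=C4[C@@H](CC3=O)[C@H](C(=O)OC)C[C@@]42CN(C)C1` share one core and differ at a single point. In a functional assay on SW480 cells (Homo sapiens) for cytotoxicity, read by MTT assay, with a stated time of 48 h (a higher number here means a weaker inhibitor, a lower number a stronger inhibitor), compound 1 gives > 40000 nM, which is a limit of the assay rather than a number. In this assay compound 2 gives > 40000 nM, again a limit. The change between them is methyl in place of hydrogen on a saturated chain carbon bound to an oxygen on a saturated carbon, and the step that the two limits leave unreadable from compound 2 to compound 1 cannot be sized because the limit of > 40000 nM in this assay, at which 3 of the 3 values shown sit, holds both of its values.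

Compound 3 `CCC1=CCC2(CO1)[C@@H]1CCC3=C4[C@H](CC3=O)[C@H](C(=O)OC)C[C@@]42CN(C)C1` rests on a different core; how its core differs from that of compound 2 is not broken down here. In this assay compound 3 gives > 40000 nM, which is a limit. Compound 4 `COC(=O)[C@@H]1C[C@@]23CN(C)C[C@@H](CCC4=C2[C@@H]1CC4=O)C31CC=C(C(C)C)OC1` is not yet measured and differs from compound 3 by methyl in place of hydrogen on a saturated chain carbon bound to a double-bonded ring carbon and a saturated chain carbon. This is the same kind of change as that from compound 2 to compound 1, but not the same: in the first pair it sits on a saturated chain carbon bound to an oxygen on a saturated carbon, in the second on a saturated chain carbon bound to a double-bonded ring carbon and a saturated chain carbon. Since every measured value stands at the limit of > 40000 nM in this assay, at which 3 of the 3 values shown sit, the author expects the step that the limit leaves unreadable from compound 3 to compound 4 to be negligible. He estimates that compound 4 will give about 45000 nM in this assay, between 15000 nM and 150000 nM, and most probably only a limit once more.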

Compound 4, half-maximal inhibitory concentration: > 40000 nM
Compound 4 was reported as a limit (the forecaster's own chance of this, stated with the estimate: 80%); the middle value is on the limit's open side.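

In this assay compound 4 gives > 40000 nM as a limit. No step can be read from compound 3 to compound 4, because both values stand at the same limit: the limit of > 40000 nM in this assay, at which 4 of the 4 values shown sit. The compounds shown leave open how far each lies past that limit in this assay and whether the change from ethyl to isopropyl has any effect on cytotoxicity here.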